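A few compounds are considered here, and "the series" means these few. Any claim that something is new, unique, unknown or untested is made for them only; others in the source may bear on it.

Measured in a functional assay on NCI-H520 cells (Homo sapiens); a higher number here means a weaker inhibitor of growth, a lower number a stronger inhibitor of growth:
- compound 1 `O=S(=O)(/C=C/c1ccc(Cl)cc1)Cc1ccc(Nc2ncnc3ccccc23)cc1` gives 46000 nM
- compound 2 `O=S(=O)(/C=C/c1ccc(Br)cc1)Cc1ccc(Nc2ncnc3ccc(Br)cc23)cc1` gives 20000 nM

Of these two, compound 2 has the lower number at 20000 nM and is therefore the stronger inhibitor of growth, and its gap to compound 1 lies beyond the usual scatter. Compound 3 `O=S(=O)(/C=C/c1ccc(Cl)cc1)Cc1ccc(Nc2ncnc3ccc(Br)cc23)cc1` has not yet been measured. It differs from compound 2 by chloro in place of bromo on an aromatic carbon, para to a large group (chloro in place of bromo on an aromatic carbon). Within the data shown here, no measured pair shows this exchange alone, so no step beyond the scatter is expected in this assay. Compound 1, which also carries the 4-chlorophenyl, gives 46000 nM, so any small drift would more likely be upward. The estimated step of a 1.3-fold higher number from compound 2 to compound 3 (0.10 log units; within the scatter) stays within the scatter. For compound 3 the expected value is 25000 nM, with an estimated range of 11000 nM to 50000 nM.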

Compound 3, concentration for 50% growth inhibition: 13000 nM
Beside the measured number, compound 3's estimate is 1.9-fold (0.28 log units) above it; low and high end bracket the measured number.
By their numbers in this assay, from the lowest: compounds 3 and 2 (each within the scatter of the next); then compound 1.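

In this assay, the change from 4-bromophenyl to 4-chlorophenyl gives a 1.5-fold lower number from compound 2 to compound 3 (0.19 log units; within the scatter), so with the bromo on the core in place, this position shows no measurable preference between the two halogens. Among these compounds, the first single-place comparison for the other bromo gives a 3.5-fold lower number from compound 1 to compound 3 (0.55 log units; beyond the scatter), a modest step beyond the scatter that comes with bromo in place of hydrogen on an aromatic carbon, whereas the halogen exchange stays within it. Nothing available explains either result.

The three compounds leave open whether a group other than a halogen, such as a methoxy group or an amine, would be accepted in place of the chloro of the 4-chlorophenyl. They also leave open whether a methoxy group or a nitrile could stand in for the bromo on the core.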